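Aminothiophene amides: from piperazinyl amide to isobutylamide

The source may report more compounds than this note shows. Statements on the series, on what has been measured and on what is new or still open speak of the compounds shown alone.

This account follows a single step in a series of aminothiophene amides tested in a functional assay on PC-3 cells (Homo sapiens) for inhibition, read by sulforhodamine B assay, with a stated time of 72 h; on this read-out lower numbers stand for stronger inhibition and higher numbers for weaker inhibition. Within the data shown here, compound 1, `CN1CCN(C(=O)c2c(N)sc(-c3ccc(Cl)cc3)c2-c2ccc(Cl)cc2)CC1`, is the only member with a number: in this assay compound 1 gives 13100 nM, a weak result and the sole reference point for the series. Compound 2, `CS(=O)(=O)Nc1sc(-c2ccc(Cl)cc2)c(-c2ccc(Cl)cc2)c1C(=O)NC1CC1`, carries a methanesulfonamide and a cyclopropyl amide, but for compound 2 this assay records "not determined" (no result reported), so it offers no comparison.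

Compound 3, `CC(C)CNC(=O)c1c(N)sc(-c2ccc(Cl)cc2)c1-c1ccc(Cl)cc1`, differs from compound 1 in one place: isobutylamino in place of 4-methylpiperazin-1-yl on a carbonyl carbon. Among the measured compounds shown here, with no pair of measured compounds to show what such a change does, the size of the step rests on expectation alone. The step is expected to be modest, most likely toward somewhat stronger inhibition, but not far beyond the scatter of repeated runs, so that the estimated step of a 1.6-fold lower number from compound 1 to compound 3 (0.21 log units; within the scatter) stays small. Compound 3 is therefore expected to give about 8000 nM, within a range from 2000 nM to 30000 nM.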

Compound 3, half-maximal inhibitory concentration: 13200 nM
For compound 3 the middle estimate is 1.7-fold (0.22 log units) below the measured one; the range from low to high includes it.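

In this assay, among these compounds, replacing 4-methylpiperazin-1-yl with isobutylamino on the carbonyl carbon gives a 1.0-fold higher number from compound 1 to compound 3 (0.00 log units; within the scatter), the first step that can be read, and it leaves the two amides within the scatter of each other. This position therefore accepts an open isobutylamino chain with a hydrogen-bond donor in place of the ring with its hydrogen-bond acceptor, and the read-out does not separate the two. Nothing shown here speaks to why the two amides read alike.

Going by these compounds, it remains open whether any other group on this carbonyl carbon would move the number beyond the scatter, such as a longer chain like n-hexylamino, a benzylamino group or a chain ending in a carboxylic acid. On these data alone, the methanesulfonamide of compound 2 also remains without a number, so the effect of changing the amine on the shared core stays unknown.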